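This account rests on a few compounds, and the source may have more. Where it says the series, first, only, none or still open, it means among the compounds named here.

Series notes, aryl ketones on a shared core, read in a functional assay on K562 cells (Homo sapiens) for antiproliferative activity, read by MTT assay, with a stated time of 72 h; on this read-out lower numbers stand for stronger inhibition and higher numbers for weaker inhibition.

Going by the values given here, compound 1 `COc1cc(C(=O)c2sc3ccccc3c2-c2ccccc2)cc(OC)c1OC` gives 2100 nM in this assay, the second highest of the three numbers so far. Compound 2 `COc1cc(C(=O)c2sc3ccccc3c2-c2ccc(Cl)cc2)cc(OC)c1OC` gives 4200 nM and compound 3 `COc1cc(C(=O)c2sc3ccccc3c2-c2ccc(SC)cc2)cc(OC)c1OC` gives 1800 nM; the step of a 2.0-fold higher number from compound 1 to compound 2 (0.30 log units; within the scatter) and the step of a 1.2-fold lower number from compound 1 to compound 3 (0.07 log units; within the scatter) both stay within the scatter, while a 2.3-fold lower number from compound 2 to compound 3 (0.37 log units; beyond the scatter) is modest.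

Compound 4 `COc1ccc(-c2c(C(=O)c3cc(OC)c(OC)c(OC)c3)sc3ccccc23)c(OC)c1` differs from compound 1 by 2,4-dimethoxyphenyl in place of phenyl on an aromatic carbon. Among the compounds with values here, only the steps from compound 1 to compound 2 and to compound 3 bear on it, and each was small; nothing measured carries two methoxy groups on that ring. For compound 4 the expected step is a 1.3-fold lower number from compound 1 to compound 4 (0.12 log units; within the scatter), that is no clear shift beyond the scatter, and the estimate in this assay is 1600 nM with a range of 500 nM to 5000 nM.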

Compound 4, half-maximal inhibitory concentration: 4100 nM
Compound 4: the middle estimate sits 2.6-fold (0.41 log units) below what was measured; the range from low to high includes it.
By their numbers in this assay, from the lowest: compounds 3, 1, 4 and 2 (each within the scatter of the next, the first and the last beyond it).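

In this assay, 2,4-dimethoxyphenyl on this aromatic carbon stays within the scatter of phenyl (a 2.0-fold higher number from compound 1 to compound 4 (0.29 log units; within the scatter)) and of 4-chlorophenyl (a 1.0-fold lower number from compound 2 to compound 4 (0.01 log units; within the scatter)), so adding two methoxy groups to the ring gives no clear shift from either. Only 4-(methylsulfanyl)phenyl separates from it, by a modest step (a 2.3-fold higher number from compound 3 to compound 4 (0.36 log units; beyond the scatter)). No measurement at hand accounts for these steps.

On these data alone, what a single methoxy group on this ring would give remains open. So does the outcome with an amine or a carboxylic acid there.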